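A Chloro Added to the Benzyl Group of Compound 2

The source may report more compounds than this note shows. Statements on the series, on what has been measured and on what is new or still open speak of the compounds shown alone.

Compound 1 `CN(C)Cc1ccc2nc(NC(=O)N/N=C/c3cn(Cc4ccccc4Cl)c4ccccc34)sc2c1`: 1600 nM
Compound 2 `CN(C)Cc1ccc2nc(NC(=O)N/N=C/c3cn(Cc4ccccc4)c4ccccc34)sc2c1`: 400 nM

Among the measured compounds shown here, in a functional assay on NCI-H460 cells (Homo sapiens) for cytotoxicity, read by MTT assay, with a stated time of 72 h (on this read-out higher numbers stand for weaker inhibition and lower numbers for stronger inhibition), compound 2 holds the lower of the two numbers measured so far, at 400 nM. Compound 3 `CN(C)Cc1ccc2nc(NC(=O)N/N=C/c3cn(Cc4ccc(Cl)cc4)c4ccccc34)sc2c1` departs from it in one place: chloro in place of hydrogen on an aromatic carbon. This is chloro in place of hydrogen on an aromatic carbon, para to a large group, turning benzyl into 4-chlorobenzyl.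

Compound 1 also carries a chloro on an aromatic carbon of its benzyl group, though not at the place where compound 3 carries one. For the measured compounds named here, it provides the only measured step that bears on the change. Hydrogen in place of that chloro gave a 4.0-fold lower number from compound 1 to compound 2 (0.60 log units; beyond the scatter). Since the chloro stands elsewhere, this step is only a partial guide, and a single step shows no pattern. Read in reverse, it points towards a higher number in this assay, and a smaller rise is expected here. The expected change is a 2.3-fold higher number from compound 2 to compound 3 (0.35 log units; beyond the scatter). For compound 3 the estimated value is 900 nM, with an expected range from 300 nM to 2500 nM.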

Compound 3, half-maximal inhibitory concentration: 290 nM
Beside the measured number, compound 3's estimate is 3.1-fold (0.49 log units) above it, outside the stated range (below it).
By their numbers in this assay, from the lowest: compounds 3 and 2 (each within the scatter of the next); then compound 1.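

The new compound shows that this position takes a chloro without a clear cost in this assay: chloro in place of hydrogen on the aromatic carbon para to a large group gives a 1.4-fold lower number from compound 2 to compound 3 (0.14 log units; within the scatter), so benzyl and 4-chlorobenzyl cannot be told apart on this read-out. The loss that came with the chloro in the earlier pair therefore does not follow from a chloro on the benzyl ring as such, but depends on where on that ring it stands, as the change of its place shows with a 5.5-fold lower number from compound 1 to compound 3 (0.74 log units; beyond the scatter). Nothing available explains this dependence on place.

The compounds shown leave open whether the same place would accept groups other than chloro, such as a fluoro, a methoxy, a trifluoromethyl or a dimethylamino group, and whether a larger one such as phenyl would fit the same trend. They also leave open whether the dependence on place, which rests on a single pair of chloro isomers in one cell line, would hold for a bromo or a methyl group.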